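The source may hold more compounds than are shown below. What is called first, only, known or untested is meant among the compounds shown, and "the series" means these compounds.

Compound 3, whose structure is `COC(=O)[C@H](CCSC)NC(=O)c1ccc(NCc2cncn2Cc2ccc(Cl)cc2)cc1-c1ccccc1`, is one of three close relatives that share a core and differ only in the substituent on the outer benzyl ring. In a functional assay on NIH3T3 cells (Mus musculus) (on this read-out higher numbers stand for an effect only at larger amounts of compound and lower numbers for an effect already at smaller amounts), compound 3 gives > 10 uM, which is a limit of the assay and not a number. Compound 1, `COC(=O)[C@H](CCSC)NC(=O)c1ccc(NCc2cncn2Cc2ccc(C)cc2)cc1-c1ccccc1`, carries a methyl where compound 3 carries chloro. In this assay compound 1 gives > 10 uM, again a limit. Compound 2, `CSCC[C@H](NC(=O)c1ccc(NCc2cncn2Cc2cccc(C)c2)cc1-c1ccccc1)C(=O)O`, carries its methyl at another place on that ring and has the free acid in place of the methyl ester. In this assay compound 2 gives > 10 uM, also a limit. For the measured compounds named here, the only single-point step among the measured compounds, a step that the two limits leave unreadable from compound 1 to compound 3, is therefore unreadable in size. Compound 3 thus stands only at a limit, and the same holds for the two further values shown, as the limit of > 10 uM in this assay, at which 3 of the 3 values shown sit, makes plain.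

Compound 4, `COC(=O)[C@H](CCSC)NC(=O)c1ccc(NCc2cncn2Cc2ccc(C#N)cc2)cc1-c1ccccc1`, differs from compound 3 by cyano in place of chloro on an aromatic carbon. Going by the values given here, no measured step gives a readable size that would bear on this change, since every value shown sits at the limit. Compound 3 at its limit gives no footing for a direction, so no step beyond the scatter is expected, and the estimated step that the limit leaves unreadable from compound 3 to compound 4 is close to nil. For compound 4 the expected value in this assay is 20 uM, with a range from 5 uM to 80 uM.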

Compound 4, concentration for half-maximal effect: > 10 uM
Compound 4: no number, only a limit; the forecaster's own chance of this, stated with the estimate: 75%; the middle value lies beyond the limit too.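

In this assay compound 4 gives > 10 uM, which is a limit of the assay and not a number. The steps to it from compound 1 and compound 3 cannot be read, so no new step emerges: the limit of > 10 uM in this assay, at which 4 of the 4 values shown sit.

The compounds shown leave open how far each lies from that limit, and whether changes on the outer benzyl ring shift the read-out at all.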